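Changing the Amide Group on a Shared Core

The source may hold more compounds than are shown below. What is called first, only, known or untested is meant among the compounds shown, and "the series" means these compounds.

In a functional assay on PC-3 cells (Homo sapiens) for antiproliferative activity, read by MTT assay, with a stated time of 48 h (a higher number here means a weaker inhibitor, a lower number a stronger inhibitor), three compounds built on one shared core have been measured. Compound 1 (`C=CCN(C)C(=O)c1ccc(C(CC)(CC)c2ccc(OCCC(O)(CC)CC)c(C)c2)n1CC`) gives 12800 nM, compound 2 (`CCn1c(C(=O)Nc2cccc(C(F)(F)F)c2)ccc1C(CC)(CC)c1ccc(OCCC(O)(CC)CC)c(C)c1`) gives 23800 nM, and compound 3 (`CCC(C)C(NC(=O)c1ccc(C(CC)(CC)c2ccc(OCCC(O)(CC)CC)c(C)c2)n1CC)C(=O)O`) gives 13800 nM. The last of these stands within the scatter of both others, as the numbers show: a 1.1-fold higher number from compound 1 to compound 3 (0.03 log units; within the scatter) and a 1.7-fold lower number from compound 2 to compound 3 (0.24 log units; within the scatter).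

Compound 4 (`CCn1c(C(=O)N(C)CCO)ccc1C(CC)(CC)c1ccc(OCCC(O)(CC)CC)c(C)c1`) is the next case, and its difference from the preceding compound is this: (2-hydroxyethyl)(methyl)amino in place of (1-carboxy-2-methylbutyl)amino on a carbonyl carbon. In words, (2-hydroxyethyl)(methyl)amino takes the place of (1-carboxy-2-methylbutyl)amino on a carbonyl carbon. All three measured steps bear on this change, as each exchanges the group on that same carbonyl carbon. The remaining one is a 1.9-fold higher number from compound 1 to compound 2 (0.27 log units; within the scatter), so even the change from allyl(methyl)amino to (3-(trifluoromethyl)phenyl)amino did not leave the scatter. Among these three compounds, no exchange at this place has yet moved the number measurably, and no measured compound carries the hydroxyl-bearing group itself. No step beyond the scatter is therefore expected in this assay.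

The expected change is a 1.1-fold higher number from compound 3 to compound 4 (0.04 log units; within the scatter). The estimate for compound 4 is 15000 nM, with an expected range from 7000 nM to 32000 nM.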

Compound 4, half-maximal inhibitory concentration: 3090 nM
Compound 4: middle estimate off by 4.9-fold (0.69 log units), on the high side; measured number below the stated range.
By their numbers in this assay, from the lowest: compound 4; then compounds 1, 3 and 2 (each within the scatter of the next).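

Among these compounds, at the carbonyl carbon, the exchange that brings in (2-hydroxyethyl)(methyl)amino is the first to move the number beyond the scatter in this assay, with a 4.5-fold lower number from compound 3 to compound 4 (0.65 log units; beyond the scatter) as its step. Compound 4 also stands apart from the other two compounds, with a 7.7-fold lower number from compound 2 to compound 4 (0.89 log units; beyond the scatter) and, where hydroxymethyl replaces vinyl on a saturated chain carbon bound to an amide-type nitrogen, a 4.1-fold lower number from compound 1 to compound 4 (0.62 log units; beyond the scatter) so that it is the strongest inhibitor of the four. The last step is the narrowest structural change of the three, and since compound 1 also carries a methyl on that nitrogen, the methyl alone does not go with the lower number. No measurement shown here accounts for this difference.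

As far as these compounds go, whether the hydroxyl itself matters remains open, since a methoxy group or an amine at the end of the same chain would separate it from the chain that carries it. Also unsettled are the roles of the methyl on the nitrogen and the chain length, which (2-hydroxyethyl)amino and a longer hydroxyalkyl chain would address.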